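The compounds below may be only part of what the source reports. "The series", "measured", "known", "first", "only" and "open" are said of these compounds alone.

Measured compounds:
compound 1 `C[C@@H](C(=O)O)c1nn(Cc2cn3cc(OCC4CC4)c(Cl)cc3n2)c2ccccc2c1=O`: 182 nM
compound 2 `O=C(O)Cc1nn(Cc2cn3cc(OCC4CC4)c(Cl)cc3n2)c2ccccc2c1=O`: 4.8 nM
compound 3 `C[C@H](C(=O)O)n1nc(Cn2cc3cc(OCC4CC4)c(Cl)cc3n2)c2ccccc2c1=O`: 3.5 nM

In a functional assay on HFL1 cells for antagonist activity at sphingosine 1-phosphate receptor 2 (Homo sapiens), read by ELISA, with a stated time of 24 h (a higher number here means a weaker inhibitor, a lower number a stronger inhibitor), compound 1 gives the highest number of the three; compound 2 and compound 3 both sit far lower. Compound 4 `CCC(C(=O)O)c1nn(Cc2cn3cc(OCC4CC4)c(Cl)cc3n2)c2ccccc2c1=O` differs from compound 1 by 1-carboxypropyl in place of 1-carboxyethyl on an aromatic carbon. Within the data shown here, the one measured step that bears on this place runs the other way: going from compound 1 to compound 2 removes the methyl from that carbon and gives a 38-fold lower number from compound 1 to compound 2 (1.58 log units; beyond the scatter). Adding a carbon instead of removing one therefore gives no reason to expect a stronger inhibitor; a modest move toward a higher number, or none beyond the scatter, seems most likely. Compound 4 is estimated at 400 nM in this assay, within 130 nM to 1300 nM, meaning an expected 2.2-fold higher number from compound 1 to compound 4 (0.34 log units; beyond the scatter).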

Compound 4, half-maximal inhibitory concentration: 5.6 nM
Compound 4: middle estimate off by 71-fold (1.85 log units), on the high side; measured number below the stated range.
By their numbers in this assay, from the lowest: compounds 3, 2 and 4 (each within the scatter of the next); then compound 1.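

In this assay, a substituent on this carbon does not by itself raise the number: ethyl in place of hydrogen gives a 1.2-fold higher number from compound 2 to compound 4 (0.07 log units; within the scatter), and 1-carboxypropyl in place of 1-carboxyethyl gives a 33-fold lower number from compound 1 to compound 4 (1.51 log units; beyond the scatter). The high number is thus particular to compound 1, whose 1-carboxyethyl carries a defined stereocentre, whereas the 1-carboxypropyl of compound 4 carries none. No evidence at hand explains this difference.

The compounds shown leave open how the opposite stereocentre of the 1-carboxyethyl group would read, and how each separate stereo form of the 1-carboxypropyl group would compare. They also leave open whether a longer chain, such as 1-carboxybutyl, would stay in the same range.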